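Shortening the Halogenated Acyl Chain on a Shared Core

The source may hold more compounds than are shown below. What is called first, only, known or untested is meant among the compounds shown, and "the series" means these compounds.

Two amides built on one shared core have been measured in a functional assay on MGC-803 cells (Homo sapiens) for inhibition, read by MTT assay, with a stated time of 48 h; a lower number here means a stronger inhibitor, a higher number a weaker inhibitor. Compound 1 `COc1ccc(CN(C(=O)C(C)Br)c2cc(OC)c(OC)c(OC)c2)cc1O` carries a 1-bromoethyl group on the carbonyl carbon, and in this assay compound 1 gives 120 nM. Compound 2 `COc1ccc(CN(C(=O)CCCl)c2cc(OC)c(OC)c(OC)c2)cc1O` carries a 2-chloroethyl group there instead, and in this assay compound 2 gives 140 nM. The step of a 1.2-fold higher number from compound 1 to compound 2 (0.07 log units; within the scatter) changed both the halogen and the chain, yet the two numbers sit within the scatter of each other. For the measured compounds named here, compound 2 thus holds the highest of the two numbers so far, and its only neighbour, compound 1, lies within the scatter of it.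

Compound 3 `COc1ccc(CN(C(=O)CBr)c2cc(OC)c(OC)c(OC)c2)cc1O` has not yet been measured. It differs from compound 2 by bromo in place of chloromethyl on a saturated chain carbon bound to a carbonyl carbon, so that a (2-chloroethyl)carbonyl becomes a (bromomethyl)carbonyl. Going by the values given here, only the step from compound 1 to compound 2 bears on this change, and it stayed within the scatter; no measured pair separates the halogen from the chain length. The expected step of a 1.1-fold lower number from compound 2 to compound 3 (0.03 log units; within the scatter) is therefore small, with no clear direction. The estimate for compound 3 in this assay is 130 nM, with a range from 55 nM to 310 nM.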

Compound 3, half-maximal inhibitory concentration: 140 nM
The estimate for compound 3 lay 1.1-fold (0.03 log units) below the measured number; measured number inside the range.
By their numbers in this assay, from the lowest: compounds 1, 2 and 3 (each within the scatter of the next).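

Compound 3 pulls apart a change that the first two compounds left tied together: with the bromine kept, hydrogen in place of methyl on the saturated chain carbon bound to a bromine atom and a carbonyl carbon gives a 1.2-fold higher number from compound 1 to compound 3 (0.07 log units; within the scatter) in this assay, so the methyl on this carbon makes no difference that can be read here. The other step, bromo in place of chloromethyl, gives no change at the digits printed from compound 2 to compound 3 (within the scatter) and so also stays inside the scatter, which means that in these three compounds the 1-bromoethyl, 2-chloroethyl and bromomethyl groups cannot be told apart on the carbonyl carbon. Nothing on hand explains why these numbers sit so close together.

Every acyl group shown still carries a halogen, so it remains open whether a plain ethyl group, an amine or a longer chain in this place would hold the number or move it beyond the scatter. The compounds shown also contain no pair that swaps chlorine for bromine on an otherwise identical chain, so the halogen on its own remains unseparated from the chain.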